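Moving the Tetrazole Out on a Methoxy Linker

The source may report more compounds than this note shows. Statements on the series, on what has been measured and on what is new or still open speak of the compounds shown alone.

Of the compounds shown here, three have so far been measured in a functional assay (ileum) for inhibition, with Cavia porcellus as the target; on this read-out higher numbers stand for weaker inhibition and lower numbers for stronger inhibition. Compound 2 `O=C(/C=C/c1cccc(/C=C/c2ccc3ccccc3n2)c1)c1cc(-c2nn[nH]n2)ccc1O` gives 46 nM, the lowest of the three numbers. Compound 3 `O=C(O)c1cccc(C(=O)/C=C/c2cccc(/C=C/c3ccc4ccccc4n3)c2)c1O` gives 56 nM in this assay, a value within the scatter of that of compound 2, so the two cannot be told apart. Compound 1 `Cn1c(COc2ccc(/C=C/C(=O)c3cc(-c4nn[nH]n4)ccc3O)cc2)nc2ccccc21` gives 190 nM, which lies beyond the scatter above the number of compound 2.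

Compound 4 `O=C(/C=C/c1cccc(/C=C/c2ccc3ccccc3n2)c1)c1cc(OCc2nn[nH]n2)ccc1O` has not yet been measured. It differs from compound 2 in one place: (2H-tetrazol-5-yl)methoxy in place of 2H-tetrazol-5-yl on an aromatic carbon. Within the data shown here, no measured pair shows a change of this kind, so its effect is unknown from the data. Compound 2 and compound 3 carry different groups at this same place and give numbers within the scatter of each other, which hints that this position tolerates some change, while compound 1 shows that change elsewhere can matter. A modest rise in the number is expected, estimated as a step of a 2.6-fold higher number from compound 2 to compound 4 (0.42 log units; beyond the scatter). The estimate for compound 4 in this assay is 120 nM, with a range from 30 nM to 500 nM.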

Compound 4, half-maximal inhibitory concentration: 23 nM
The estimate for compound 4 lay 5.2-fold (0.72 log units) above the measured number; measured number below the stated range.
By their numbers in this assay, from the lowest: compounds 4, 2 and 3 (each within the scatter of the next, the first and the last beyond it); then compound 1.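

In this assay, placing (2H-tetrazol-5-yl)methoxy where 2H-tetrazol-5-yl stood gives a 2.0-fold lower number from compound 2 to compound 4 (0.30 log units; within the scatter), a step within the scatter, so the two compounds cannot be told apart. This is the first single-place change shown at this position, and it shows that the tetrazole ring need not sit directly on the aromatic carbon: with the ring held further out on the methoxy linker, the number stays in the same range. No measurement of any other kind is available to explain this result.

What remains open is how far this tolerance extends, since only one linker length is shown. A longer chain such as ethoxy carrying the tetrazole, or a carboxylic acid on the same methoxy linker in place of the ring, could show whether the tetrazole itself matters here.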